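Sulfonyl aryl swap and hepatic clearance in a quinoline series

A few compounds are considered here, and "the series" means these few. Any claim that something is new, unique, unknown or untested is made for them only; others in the source may bear on it.

Measured so far:
compound 1 `COc1ccc(-c2c(S(=O)(=O)c3ccc(F)c(F)c3)cnc3cc(F)ccc23)cc1`: 1.1 mL/min
compound 2 `O=S(=O)(c1ccc(F)c(Cl)c1)c1cnc2cc(F)ccc2c1-c1cccc(F)c1`: 0.25 mL/min
compound 3 `COc1cccc(S(=O)(=O)c2cnc3cc(F)ccc3c2-c2cccc(F)c2)c1`: 3.36 mL/min

In an ADME assay on microsomes from liver (Homo sapiens) for metabolic stability, tested at 2.5 uM (on this read-out higher numbers stand for fast clearance and lower numbers for slow clearance), compound 3 stands highest of the three numbers, with compound 1 nearest and compound 2 furthest. Compound 4 `O=S(=O)(c1ccc(F)c(F)c1)c1cnc2cc(F)ccc2c1-c1cccc(F)c1` is not yet measured; it differs from compound 3 in one place: 3,4-difluorophenyl in place of 3-methoxyphenyl on a sulfonyl sulfur. Within the data shown here, one measured step bears on this, the reverse of a 13-fold higher number from compound 2 to compound 3 (1.13 log units; beyond the scatter), where 3-chloro-4-fluorophenyl on the sulfonyl sulfur gave way to 3-methoxyphenyl. Run the other way, a large drop is expected. Compound 1, which also carries 3,4-difluorophenyl on its sulfonyl sulfur, gives 1.1 mL/min. Compound 4 is therefore expected at 0.45 mL/min, within 0.2 mL/min to 1.1 mL/min. That estimate means a 7.5-fold lower number from compound 3 to compound 4 (0.87 log units; beyond the scatter).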

Compound 4, intrinsic clearance in a liver preparation (reported as CLH), per the amount of preparation that the assay uses: 0.6 mL/min
Beside the measured number, compound 4's estimate is 1.3-fold (0.12 log units) below it, within the range that was stated.
By their numbers in this assay, from the lowest: compound 2; then compounds 4 and 1 (each within the scatter of the next); then compound 3.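

In this assay, the high number of compound 3 now reads as tied to 3-methoxyphenyl on the sulfonyl sulfur against a second halogenated aryl group, with a 5.6-fold lower number from compound 3 to compound 4 (0.75 log units; beyond the scatter) as 3,4-difluorophenyl enters. Among these compounds, the single halogen swap also registers, with a 2.4-fold higher number from compound 2 to compound 4 (0.38 log units; beyond the scatter) as fluoro replaces chloro on an aromatic carbon, so the two halogenated groups are distinguishable at this position. The other aryl change, with a 1.8-fold lower number from compound 1 to compound 4 (0.26 log units; within the scatter) as 3-fluorophenyl replaces 4-methoxyphenyl on an aromatic carbon, stays unresolved. Nothing available explains these steps.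

As far as these compounds go, how an amine or a carboxylic acid on the sulfonyl aryl ring would read remains open.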